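The compounds below may be only part of what the source reports. "The series", "measured", "known", "first", "only" and "open" are said of these compounds alone.

Of the compounds shown here, two with one shared core have been tested in an ADME assay on Huh-7 cells (Homo sapiens) for cytotoxicity, with a stated time of 3 days; on this read-out lower numbers stand for higher toxicity in this test and higher numbers for lower toxicity in this test. Compound 1 `O=C(Nc1ccc(Cl)cc1)c1c(NO)cc(-c2cccs2)oc1=O` carries a chloro group on its outer aromatic ring; in this assay compound 1 gives > 20000 nM, which is a limit of the assay and not a number. Compound 2 `Cc1ccc(NC(=O)c2c(NO)cc(-c3cccs3)oc2=O)cc1` carries a methyl group there instead; in this assay compound 2 gives > 20000 nM, which is also a limit. The step that the two limits leave unreadable from compound 1 to compound 2 cannot be sized, since both values sit at the limit of > 20000 nM in this assay, at which 2 of the 2 values shown sit. So compound 2 stands at the top edge of what this assay reports, among the least toxic outcomes the test can show.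

Compound 3 `COc1ccc(NC(=O)c2c(NO)cc(-c3cccs3)oc2=O)cc1` has not yet been measured. It differs from compound 2 in one place: methoxy in place of methyl on an aromatic carbon. Going by the values given here, only one measured step bears on this change, and it is unreadable, so there is no measured guide to its direction or size. The expected step for compound 3 is a step that the limit leaves unreadable from compound 2 to compound 3, that is, none beyond the scatter. The estimate for compound 3 in this assay is 30000 nM, with a range from 15000 nM to 80000 nM, most likely reported as a limit.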

Compound 3, half-maximal cytotoxic concentration: > 20000 nM
Compound 3 was reported as a limit (the forecaster's own chance of this, stated with the estimate: 85%); the middle value lies beyond the limit too.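

No step can be read among compound 1, compound 2 and compound 3, since each result is a limit of the assay and not a number: the limit of > 20000 nM in this assay, at which 3 of the 3 values shown sit.

The compounds shown leave open whether swapping chloro, methyl and methoxy on the outer ring changes the result at all in this assay, since any difference would lie beyond that limit.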